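Bromo to iodo on the shared core: an expected flat step

The source may report more compounds than this note shows. Statements on the series, on what has been measured and on what is new or still open speak of the compounds shown alone.

Measured compounds:
- compound 1 `COc1ccc(-c2cc(=O)c3c(OC)cc(OC)cc3[nH]2)cc1`: "not determined" (no result reported)
- compound 2 `COc1ccc(-c2cc(=O)c3c(OC)cc(OC)cc3n2Cc2ccccc2)cc1`: "not determined" (no result reported)
- compound 3 `COc1ccc(-c2c(Br)c(=O)c3c(OC)cc(OC)cc3n2S(=O)(=O)c2ccc(OC)cc2)cc1`: 69000 nM

In an ADME assay on THLE-2 cells (Homo sapiens) for antiproliferative activity, with a stated time of 72 h (a lower number here means that less compound is needed, a higher number that more compound is needed for the effect), only compound 3 has a number; compound 1 and compound 2 carry no result in this assay. Compound 3 therefore stands alone on the numbers shown, and no step between two measured compounds can be drawn from it. The half-maximal effective concentration of compound 3 in this assay is high, so a large amount of it is needed for the antiproliferative effect.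

Compound 4 `COc1ccc(-c2c(I)c(=O)c3c(OC)cc(OC)cc3n2S(=O)(=O)c2ccc(OC)cc2)cc1` has not yet been measured. It differs from compound 3 in one place only: iodo in place of bromo on an aromatic carbon. Among the measured compounds shown here, with no comparable step among the measured compounds, the account can rest only on the single value of compound 3 and on how small the change is, a swap of one halogen for another at the same place. The step expected for this change in this assay is no change at the digits printed from compound 3 to compound 4 (within the scatter), which is not expected to exceed the usual scatter of repeated measurements in either direction. Compound 4 is accordingly estimated at 69000 nM, with a plausible range from 30000 nM to 160000 nM.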

Compound 4, half-maximal effective concentration: 57000 nM
The estimate for compound 4 lay 1.2-fold (0.08 log units) above the measured number; low and high end bracket the measured number.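

In this assay, among the compounds shown here, iodo in place of bromo on an aromatic carbon gives a 1.2-fold lower number from compound 3 to compound 4 (0.08 log units; within the scatter) and so provides the first comparison between two measured compounds. At this place, ortho to a 4-methoxyphenyl group and two atoms from the ring nitrogen, the two halogens cannot be told apart in this read-out, with compound 3 at 69000 nM and compound 4 at 57000 nM both needing a large amount of compound for the effect. Nothing shown gives a reason for this result. Going by these compounds, what remains open is whether a group of another kind at this place, such as an amine, a carboxylic acid or a longer chain, would give a step beyond the scatter. With no number for compound 1 or compound 2, the shared core without a halogen at this place also remains unread.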